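The source may hold more compounds than are shown below. What is called first, only, known or untested is meant among the compounds shown, and "the series" means these compounds.

Measured in an assay on liver for inhibition of sterol O-acyltransferase 1 (Rattus norvegicus), using microsomes; on this read-out higher numbers stand for weaker inhibition and lower numbers for stronger inhibition:
compound 1 `CC(C)c1cc(C(C)(C)C)cc(C(C)C)c1OC(=O)NS(=O)(=O)Oc1c(C(C)C)cccc1C(C)C`: 8800 nM
compound 2 `CC(C)c1cc(Br)cc(C(C)C)c1OC(=O)NS(=O)(=O)Oc1c(C(C)C)cccc1C(C)C`: 31000 nM
compound 3 `CC(C)c1cc(F)cc(C(C)C)c1OC(=O)NS(=O)(=O)Oc1c(C(C)C)cccc1C(C)C`: a limit of the assay only, > 50000 nM

Compound 3 thus sits at the weak end of the three, at the limit (the limit of > 50000 nM in this assay, at which 1 of the 3 values shown sits). Both replacements of tert-butyl in compound 1 raised the number: a 3.5-fold higher number from compound 1 to compound 2 (0.55 log units; beyond the scatter) and an at least 5.6-fold higher number from compound 1 to compound 3 (0.75 log units; beyond the scatter). The further step an at least 1.6-fold higher number from compound 2 to compound 3 (0.20 log units; that floor lies within the scatter) rests on a floor within the scatter. Compound 4 `CC(=O)c1cc(C(C)C)c(OC(=O)NS(=O)(=O)Oc2c(C(C)C)cccc2C(C)C)c(C(C)C)c1` differs from compound 3 by acetyl in place of fluoro on an aromatic carbon. Among the compounds with values here, no measured step introduces acetyl, so only the indirect pattern applies: the group with the most heavy atoms at this position, in compound 1, gave the lowest number. Acetyl adds heavy atoms relative to fluoro, so a modest fall in the number is expected, an at least 2.0-fold lower number from compound 3 to compound 4 (0.30 log units; that floor lies within the scatter). Compound 4 is estimated at 25000 nM, range 8000 nM to 60000 nM.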

Compound 4, half-maximal inhibitory concentration: 41800 nM
Beside the measured number, compound 4's estimate is 1.7-fold (0.22 log units) below it; low and high end bracket the measured number.
By their numbers in this assay, from the lowest: compound 1; then compounds 2 and 4 (each within the scatter of the next). At a limit, above all of these: compound 3.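

In this assay, acetyl does not reach what tert-butyl gives at this position: a 4.8-fold higher number from compound 1 to compound 4 (0.68 log units; beyond the scatter). Acetyl also cannot be told apart from bromo: a 1.3-fold higher number from compound 2 to compound 4 (0.13 log units; within the scatter). Tert-butyl remains the only group set apart from the others that give a number. Acetyl in place of fluoro gives only a floor, an at least 1.1-fold lower number from compound 3 to compound 4 (0.07 log units; that floor lies within the scatter), so this step cannot be read as a change. Compound 3 stands only at a limit: the limit of > 50000 nM in this assay, at which 1 of the 4 values shown sits.

As far as these compounds go, whether another branched hydrocarbon group, such as cyclohexyl, matches or passes tert-butyl remains open. So does the reading of an amine or a carboxylic acid at this position.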